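Swapping Dimethylamino for Trifluoromethoxy at the Far End

This account rests on a few compounds, and the source may have more. Where it says the series, first, only, none or still open, it means among the compounds named here.

Compound 1 `Cc1ccc2[nH]c(-c3ccc(-c4ccc(-c5ccc(N(C)C)cc5)cc4)cc3)nc2c1` and compound 2 `CN(C)c1ccc(-c2ccc(-c3ccc(-c4nc5c(O)cccc5[nH]4)cc3)cc2)cc1` share the same core and differ only at one end of it. In a functional assay on MCF7 cells (Homo sapiens) for inhibition, read by sulforhodamine B assay (on this read-out lower numbers stand for stronger inhibition of growth and higher numbers for weaker inhibition of growth), compound 1 gives 3130 nM, the highest of the two numbers shown, with compound 2 nearest. In this assay compound 2 gives 2310 nM, and the step of a 1.4-fold lower number from compound 1 to compound 2 (0.13 log units; within the scatter) shows no difference beyond the scatter for that change of the core. Compound 3 `Cc1ccc2[nH]c(-c3ccc(-c4ccc(-c5ccc(OC(F)(F)F)cc5)cc4)cc3)nc2c1` has not yet been measured. It differs from compound 1 at the opposite end of the molecule: trifluoromethoxy in place of dimethylamino on an aromatic carbon. For the measured compounds named here, no measured step touches this end; the only step available, a 1.4-fold lower number from compound 1 to compound 2 (0.13 log units; within the scatter), concerns another position and was small, so it offers no direction for the new change. The expectation for compound 3 in this assay is therefore a step of a 1.1-fold higher number from compound 1 to compound 3 (0.05 log units; within the scatter), that is, no shift beyond the scatter, but with a wide band of uncertainty. Compound 3 is estimated at 3500 nM in this assay, within a range from 1200 nM to 10000 nM.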

Compound 3, concentration for 50% growth inhibition: 31000 nM
For compound 3 the middle estimate is 8.9-fold (0.95 log units) below the measured one; the whole stated range lies below it.
By their numbers in this assay, from the lowest: compounds 2 and 1 (each within the scatter of the next); then compound 3.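

The step at this end (a 9.9-fold higher number from compound 1 to compound 3 (1.00 log units; beyond the scatter)) shows that, in this assay, the group on this aromatic carbon can move the number beyond the scatter. For the compounds shown here, the only earlier step (a 1.4-fold lower number from compound 1 to compound 2 (0.13 log units; within the scatter)) came from a change elsewhere on the shared core and stayed within the scatter, so it gave no sign of this sensitivity. Here, replacing dimethylamino with trifluoromethoxy goes with weaker inhibition of growth, although the two groups match in the computed counts of hydrogen-bond donors and acceptors and neither carries a net charge or a ring. Nothing shown here accounts for the rise in the number.

Going by these compounds alone, with only two groups compared at this end, it remains open whether a smaller group such as methoxy, a primary amine or a bare hydrogen would sit nearer compound 1 or nearer compound 3, and so whether dimethylamino helps or trifluoromethoxy hurts. Also open, on these data alone, is whether the same swap would produce a step of similar size on compound 2, which carries the 4-hydroxy-1H-benzimidazol-2-yl group at the other end.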